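The compounds below may be only part of what the source reports. "The series", "measured", "known", "first", "only" and "open" are said of these compounds alone.

Working notes on the series. Compound 3 `Nc1cc(N)c2nc(-c3ccccc3)c(Oc3ccc(F)cc3)nc2c1` is the reference point for the next step. In a functional assay on MCF7 cells (Homo sapiens) for inhibition, read by sulforhodamine B assay, with a stated time of 48 h (a higher number here means a weaker inhibitor of growth, a lower number a stronger inhibitor of growth), compound 3 returns only a limit, < 100000 nM. Compound 1 `Nc1cc(N)c2nc(-c3ccccc3)c(Oc3ccc(Cl)c(Cl)c3)nc2c1` gives 70800 nM in this assay. Compound 2 `Nc1cc(N)c2nc(-c3ccccc3)c(NCc3ccc(F)cc3)nc2c1` likewise returns only a limit in this assay, < 100000 nM. The step that the limit leaves unreadable from compound 1 to compound 3 cannot be sized, and the same holds for a step that the limit leaves unreadable from compound 1 to compound 2 and a step that the two limits leave unreadable from compound 2 to compound 3, because the limit of < 100000 nM in this assay, at which 2 of the 3 values shown sit, leaves two of the three values without a number. Among the measured compounds shown here, compound 3 therefore sits at the edge of what this assay resolves, and compound 1 holds the only readable number in the set.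

Compound 4 `Nc1cc(N)c2nc(-c3ccccc3)c(Sc3ccc(F)cc3)nc2c1` differs from compound 3 by (4-fluorophenyl)sulfanyl in place of 4-fluorophenoxy on an aromatic carbon. For the measured compounds named here, no measured step bears directly on this exchange, and the three steps recorded so far give no readable size or direction. Compound 4 is expected to stay close to compound 3, so the step from compound 3 to compound 4 is estimated as a step that the limit leaves unreadable from compound 3 to compound 4. The expected value for compound 4 in this assay is 70000 nM, within 20000 nM to 100000 nM.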

Compound 4, concentration for total growth inhibition: 63100 nM
Beside the measured number, compound 4's estimate is 1.1-fold (0.05 log units) above it; low and high end bracket the measured number.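

Among the compounds shown here, with (4-fluorophenyl)sulfanyl on this aromatic carbon, the set gains a second readable number in this assay, so a one-place exchange at this position can be sized for the first time. It gives a 1.1-fold lower number from compound 1 to compound 4 (0.05 log units; within the scatter), so the exchange of 3,4-dichlorophenoxy for (4-fluorophenyl)sulfanyl separates nothing in this assay. The steps to compound 4 from compound 2 and from compound 3 cannot be read, and the change from 4-fluorophenoxy to (4-fluorophenyl)sulfanyl therefore has neither size nor direction: the limit of < 100000 nM in this assay, at which 2 of the 4 values shown sit.

The compounds shown leave open whether any group on this carbon moves the value beyond the scatter. A carboxylic acid or a morpholine here, in place of the aryl groups linked through oxygen or sulfur, would test that.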